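The source may report more compounds than this note shows. Statements on the series, on what has been measured and on what is new or still open speak of the compounds shown alone.

Measured so far:
Compound 1, `CCOC(=O)CN(Cc1ccccc1)c1nc(Nc2ccc(Cl)cc2)ncc1[N+](=O)[O-]`: 30900 nM
Compound 2, `CCOC(=O)CNc1nc(Nc2ccccc2)ncc1[N+](=O)[O-]`: > 100000 nM

The study rests on two measured compounds and one still to be tested. For the measured compounds named here, in a functional assay on HepG2 cells (Homo sapiens) for antiproliferative activity, read by MTT assay, with a stated time of 48 h (a higher number here means a weaker inhibitor, a lower number a stronger inhibitor), compound 1, with the structure `CCOC(=O)CN(Cc1ccccc1)c1nc(Nc2ccc(Cl)cc2)ncc1[N+](=O)[O-]`, gives 30900 nM, the only numerical value available. Compound 2, `CCOC(=O)CNc1nc(Nc2ccccc2)ncc1[N+](=O)[O-]`, reaches only > 100000 nM in this assay; this is a limit of the assay and not a number, and the line the limit of > 100000 nM in this assay, at which 1 of the 2 values shown sits, records where it sits. Going by the values given here, no two measured compounds differ from each other in a single place, so no step size has been established within this set.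

The next compound, compound 3 with the structure `CCOC(=O)CN(Cc1ccccc1)c1nc(Nc2cc(OC)c(OC)c(OC)c2)ncc1[N+](=O)[O-]`, differs from compound 1 in one place: 3,4,5-trimethoxyphenyl in place of 4-chlorophenyl on a nitrogen on an aromatic ring. Among the compounds with values here, with no measured step to rest on, only a modest movement is expected, if any beyond the usual scatter, and its direction is taken as toward a stronger inhibitor. The expected step of a 2.1-fold lower number from compound 1 to compound 3 (0.31 log units; beyond the scatter) is therefore small. Starting from compound 1 at 30900 nM, compound 3 is estimated to give 15000 nM in this assay, within a range from 3000 nM to 60000 nM.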

Compound 3, half-maximal inhibitory concentration: 37800 nM
For compound 3 the middle estimate is 2.5-fold (0.40 log units) below the measured one; the range from low to high includes it.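

Compound 3 gives the first step measured in this set, in this assay: a 1.2-fold higher number from compound 1 to compound 3 (0.09 log units; within the scatter), with 3,4,5-trimethoxyphenyl in place of 4-chlorophenyl on a nitrogen on an aromatic ring. The group entering at this position has 12 heavy atoms and 3 hydrogen-bond acceptors, against 7 heavy atoms and 0 hydrogen-bond acceptors in the group leaving, yet the two compounds stay within the usual scatter of each other, so this assay does not tell these two groups apart on the core of compound 1. The data shown offer no cause for this outcome.

On these data alone, what an amine or a carboxylic acid would do in place of 3,4,5-trimethoxyphenyl at this position remains open, as does the outcome with a short alkyl chain there instead of an aromatic ring. As far as these compounds go, compound 2 differs from compound 1 and from compound 3 in more than one place, so the part played by each of those differences also remains open.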